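This account rests on a few compounds, and the source may have more. Where it says the series, first, only, none or still open, it means among the compounds named here.

In an ADME assay on L02 cells (Homo sapiens) for cytotoxicity, read by CCK-8 assay, with a stated time of 6 days (on this read-out higher numbers stand for weaker inhibition and lower numbers for stronger inhibition), the compounds built on the shared core sit at the weak end of the scale. For compound 1 `C[C@@H](Cn1ccc(-c2ccc(C#N)c(Cl)c2)n1)NC(=O)c1ccccc1`, the result is "not determined" (no result reported). Compound 2 `C[C@@H](Cn1ccc(-c2ccc(C#N)c(Cl)c2)n1)Nc1ccccc1` gives 29400 nM. Compound 3 `C[C@@H](Cn1ccc(-c2ccc(C#N)c(Cl)c2)n1)Nc1ncccn1` gives > 30000 nM, which is a limit of the assay and not a number. Compound 3 thus stands at the limit of > 30000 nM in this assay, at which 1 of the 3 values shown sits, without a single value of its own.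

Compound 4 `Cc1ccnc(N[C@@H](C)Cn2ccc(-c3ccc(C#N)c(Cl)c3)n2)n1` differs from compound 3 by one change: methyl in place of hydrogen on an aromatic carbon. For the measured compounds named here, only one measured step comes close to this change. That step, an at least 1.0-fold higher number from compound 2 to compound 3 (0.00 log units; that floor lies within the scatter), put pyrimidin-2-yl in place of phenyl on an amine nitrogen, and it shows only a floor, so it gives no measure of what the methyl will do. No step beyond the scatter is therefore expected in this assay, and another limit is the likeliest report. The expected outcome is a number no higher from compound 3 to compound 4 (the limit leaves the size open). Compound 4 is estimated at 30000 nM, with an expected range from 15000 nM to 60000 nM.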

Compound 4, half-maximal inhibitory concentration: > 30000 nM
Compound 4 gave a limit, no number (the forecaster's own chance of this, stated with the estimate: 70%); the middle value lies on the limit itself.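

With the 4-methylpyrimidin-2-yl group, the reading in this assay stays at the limit, so adding methyl at this carbon brings no single number onto the scale, and the step between the two limited compounds cannot be read. Set against the phenyl compound, 4-methylpyrimidin-2-yl in place of phenyl on an amine nitrogen gives an at least 1.0-fold higher number from compound 2 to compound 4 (0.00 log units; that floor lies within the scatter), so this floor, like the one for the unsubstituted pyrimidin-2-yl group, shows no step beyond the scatter. The methyl compound joins the unsubstituted one at the top of the range: the limit of > 30000 nM in this assay, at which 2 of the 4 values shown sit.

On these data alone, how far compound 3 and compound 4 lie beyond that limit remains open. So does whether an amine, a carboxylic acid or a longer chain on this same carbon would give a single number in this assay.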